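Trading a pyridine for a pyridone on the shared core

The source may report more compounds than this note shows. Statements on the series, on what has been measured and on what is new or still open speak of the compounds shown alone.

Compound 2 `C[C@@H](O[C@H]1CN2C(=O)C=C(c3ccncc3)CC2[C@@H]1c1ccc(F)cc1)c1cc(C(F)(F)F)cc(C(F)(F)F)c1` gives 8.1 nM in an assay on CHO cells for displacement of a labelled ligand from Substance-P receptor (Homo sapiens), in the presence of a further agent that is not named here (on this read-out lower numbers stand for stronger inhibition and higher numbers for weaker inhibition), the lowest of the two numbers measured, with compound 1 `C[C@@H](O[C@H]1CN2C(=O)C=C(c3ccc(F)cc3)CC2[C@@H]1c1ccc(F)cc1)c1cc(C(F)(F)F)cc(C(F)(F)F)c1` at 100 nM. Compound 3 `C[C@@H](O[C@H]1CN2C(=O)C=C(c3cc[nH]c(=O)c3)CC2[C@@H]1c1ccc(F)cc1)c1cc(C(F)(F)F)cc(C(F)(F)F)c1` carries a different group on a double-bonded ring carbon: a group of 7 heavy atoms (5 carbon, 1 nitrogen, 1 oxygen; one six-membered aromatic ring with 1 hetero atom) in place of a group of 6 heavy atoms (5 carbon, 1 nitrogen; one six-membered aromatic ring with 1 hetero atom), on a double-bonded ring carbon. Among the measured compounds shown here, the only measured step, a 12-fold lower number from compound 1 to compound 2 (1.09 log units; beyond the scatter), swapped an aryl for the pyridin-4-yl group and does not test the change to compound 3, so no measured step bears on it. The expected step is a 1.9-fold higher number from compound 2 to compound 3 (0.27 log units; within the scatter), with wide uncertainty. Compound 3 is therefore estimated at 15 nM, within a range from 4 nM to 60 nM.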

Compound 3, half-maximal inhibitory concentration: 3.9 nM
Beside the measured number, compound 3's estimate is 3.8-fold (0.59 log units) above it; measured number below the stated range.
By their numbers in this assay, from the lowest: compound 3; then compound 2; then compound 1.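

The pyridin-4-yl ring can take on a carbonyl and a hydrogen-bond donor at this double-bonded ring carbon without losing inhibition in this assay: the change gives a 2.1-fold lower number from compound 2 to compound 3 (0.32 log units; beyond the scatter), modest but real. Measured against the 4-fluorophenyl group, the same ring gives a 26-fold lower number from compound 1 to compound 3 (1.41 log units; beyond the scatter), the largest step in this short series. No measurement here explains the gain. On these data alone, it remains open whether the carbonyl oxygen or the amide hydrogen matters more, and a 2-methoxypyridin-4-yl ring, with an oxygen but no amide hydrogen, would help separate the two.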